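Trimming a Benzamido Group to a Carbamoyl Group

This account rests on a few compounds, and the source may have more. Where it says the series, first, only, none or still open, it means among the compounds named here.

Compound 1 `COc1ccc([C@@H]2C/C(=N/OCc3cn(-c4ccccc4CO)nn3)c3cc(CC=C(C)C)c(OC)cc3O2)cc1` and compound 2 `COc1ccc([C@@H]2C/C(=N/OCc3cn(-c4ccc(NC(=O)c5ccccc5)cc4)nn3)c3cc(CC=C(C)C)c(OC)cc3O2)cc1` share one core and differ only in the outer substituent of the side chain. In a functional assay on MCF7 cells (Homo sapiens) for inhibition, read by sulforhodamine B assay, with a stated time of 48 h, tested at 50 uM (on this read-out higher numbers stand for more inhibition of growth at the one concentration tested and lower numbers for less inhibition of growth), compound 1 gives 100%. In this assay compound 2 gives 4%, the lowest of the two numbers recorded; its nearest neighbour, compound 1, lies a number far beyond the usual scatter higher. Compound 3 `COc1ccc([C@@H]2C/C(=N/OCc3cn(-c4ccc(C(N)=O)cc4)nn3)c3cc(CC=C(C)C)c(OC)cc3O2)cc1` keeps the whole skeleton of compound 2 and differs from it by carbamoyl in place of benzamido on an aromatic carbon. For the measured compounds named here, no step between two measured compounds matches this change, so the expectation rests on compound 2 alone and on the large gap that separates it from compound 1. Since compound 2 sits so low at 4%, an upward step is expected from compound 2 to compound 3, of modest size, a number 21 percentage points higher from compound 2 to compound 3 (beyond the scatter), but the uncertainty is wide. Compound 3 is therefore expected to reach about 25% in this assay, within a range from 0% to 65%.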

Compound 3, percent growth inhibition at one concentration: 100%
Compound 3: the middle estimate sits 75 percentage points below what was measured; the whole stated range lies below it.
By their numbers in this assay, from the lowest: compound 2; then compounds 1 and 3 (each within the scatter of the next).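

With only carbamoyl in place of benzamido on the aromatic carbon, the result in this assay is a number 96 percentage points higher from compound 2 to compound 3 (beyond the scatter), so the substituent at this one place can by itself span the whole gap on this read-out. The group that leaves and the group that enters count the same hydrogen-bond donors and acceptors, and the difference in the count lies in the heavy atoms and the six-membered aromatic ring that go with benzamido, while no measured property on hand explains the size of the step. With 4-carbamoylphenyl in place of 2-(hydroxymethyl)phenyl on the aromatic nitrogen, the result is no change at the digits printed from compound 1 to compound 3 (within the scatter), so this single-concentration read-out does not separate these two side chains.

As far as these compounds go, whether an amine, a carboxylic acid or an acetamido group on the same aromatic carbon would behave like carbamoyl or like benzamido stays open. Also open, from the compounds shown here alone, is whether compound 1 and compound 3 would stay level at lower concentrations.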